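The source may report more compounds than this note shows. Statements on the series, on what has been measured and on what is new or still open speak of the compounds shown alone.

Three compounds sharing one core are considered here, and the numerical record in a functional assay on SW480 cells (Homo sapiens) for cytotoxicity, read by sulforhodamine B assay, with a stated time of 48 h (a lower number here means a stronger inhibitor, a higher number a weaker inhibitor), is thin. Compound 1 (`COc1ccc(/C=C/C(=O)c2cccc(-c3cccc(F)c3)c2)cc1O`) has no usable result, its entry reading "not determined" (no result reported). Among the measured compounds shown here, compound 2 (`COc1ccccc1/C=C/C(=O)c1cccc(-c2cccc(F)c2)c1`) gives 16600 nM, the only number available, so it cannot yet be ranked against anything. Attention therefore turns to compound 3 (`COc1ccc(/C=C/C(=O)c2cccc(-c3cccc(F)c3)c2)cc1`), which has the same atoms as compound 2 joined differently, with 4-methoxyphenyl in place of 2-methoxyphenyl on a double-bonded chain carbon bound to a double-bonded chain carbon. For the measured compounds named here, no measured step between related compounds shows what moving the methoxy group does in this assay, so the expectation rests on compound 2 at 16600 nM alone. No step beyond the usual scatter is expected, the estimated step being a 1.4-fold lower number from compound 2 to compound 3 (0.14 log units; within the scatter). For compound 3 the estimated value is 12000 nM, with an expected range of 4000 nM to 40000 nM.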

Compound 3, half-maximal inhibitory concentration: 4510 nM
For compound 3 the middle estimate is 2.7-fold (0.43 log units) above the measured one; low and high end bracket the measured number.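

In this assay, among the compounds shown here, the move of the methoxy group appears as a 3.7-fold lower number from compound 2 to compound 3 (0.57 log units; beyond the scatter) and gives the first measured comparison in this set, one that compound 2 alone could not supply. It shows that this place on the chain, a double-bonded chain carbon bound to a double-bonded chain carbon, responds to how the methoxy group is attached to its phenyl ring, even though the atoms stay the same. Nothing at hand accounts for the difference.

Compound 1 has no number, so its steps to compound 2 and compound 3 cannot be read. From the compounds shown here alone, it also remains open whether an amine or a carboxylic acid in place of the methoxy group on the phenyl ring would keep or lose the lower number of compound 3.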